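Aziridinylquinone series: side-chain change at the ring carbon

The source may report more compounds than this note shows. Statements on the series, on what has been measured and on what is new or still open speak of the compounds shown alone.

Among the compounds with values here, compound 1 `CC1=C(N2CC2)C(=O)C(CC(C)OC(N)=O)=C(N2CC2)C1=O` carries the higher of the two numbers measured so far in a functional assay on L1210 cells (Mus musculus), with a stated time of 1 days (a lower number here means a less potent compound, a higher number a more potent compound, by a factor of ten per unit of this negative logarithm), where compound 1 gives 5.18. Compound 2 `CCCC1=C(N2CC2)C(=O)C(CCC)=C(N2CC2)C1=O` gives 4.14 in this assay, a gap beyond the scatter. Compound 3 `COC(CO)C1=C(N2CC2)C(=O)C(C)=C(N2CC2)C1=O` is not yet measured. It differs from compound 1 in one place: a group of 5 heavy atoms (3 carbon, 2 oxygen; no ring) in place of a group of 7 heavy atoms (4 carbon, 1 nitrogen, 2 oxygen; no ring), on a double-bonded ring carbon. Within the data shown here, no step between measured compounds for this kind of change is available, so the expectation rests on compound 1 alone; a modest loss is expected, the step of a number 0.38 log units lower from compound 1 to compound 3 (beyond the scatter) estimated in this assay. For compound 3 the expected value is 4.8, within 4.2 to 5.4.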

Compound 3, logarithm of the reciprocal of the active concentration, log(1/C): 5.27
Estimate against measurement, compound 3: 0.47 log units below, and the stated range covers the measured number.
By their numbers in this assay, from the lowest: compound 2; then compounds 1 and 3 (each within the scatter of the next).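

This double-bonded ring carbon accepts the exchange in this assay: 2-hydroxy-1-methoxyethyl in place of the group of 7 heavy atoms gives no readable change, with a number 0.09 log units higher from compound 1 to compound 3 (within the scatter). The two groups differ in heavy-atom count but both carry 1 hydrogen-bond donor and 2 hydrogen-bond acceptors. Nothing at hand bears on a cause for this result. Still open, from the compounds shown here alone, is whether a group without a hydroxyl, such as a plain methoxymethyl, would hold this level. Also open, going by these compounds, is how an amine or a carboxylic acid at this carbon would read.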